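A few compounds are considered here, and "the series" means these few. Any claim that something is new, unique, unknown or untested is made for them only; others in the source may bear on it.

Of the compounds shown here, three that share one core have been measured in an assay on MDA-MB-231 cells for binding affinity to C-X-C chemokine receptor type 4 (Homo sapiens), read by immunofluorescence and microscopy, with stated times of 10 min and 30 min; on this read-out higher numbers stand for an effect only at larger amounts of compound and lower numbers for an effect already at smaller amounts. Compound 1 `COc1cccc(C(=O)NCc2ccc(CNS(=O)(=O)c3ccc(C)cc3)cc2)c1` gives 10 nM in this assay, the lowest of the three numbers. Compound 2 `O=C(NCc1ccc(CNS(=O)(=O)c2ccccc2)cc1)c1ccccc1F` gives 1000 nM, and compound 3 `Cc1cccc(C(=O)NCc2ccc(CNS(=O)(=O)c3ccccc3)cc2)c1` gives 1000 nM; both of these lie beyond the scatter away from compound 1, so compound 1 is the strongest binder of the three. Compounds 2 and 3 differ from compound 1 in two places at once, so their gap to compound 1 cannot be tied to any single change. Among the compounds with values here, the only step that alters one place is no change at the digits printed from compound 2 to compound 3 (within the scatter), which shows that exchanging the ring on the carbonyl carbon left the number where it was.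

Compound 4 `Cc1ccc(S(=O)(=O)NCc2ccc(CNC(=O)c3cccnc3)cc2)cc1` has not yet been measured. It differs from compound 1 in one place: pyridin-3-yl in place of 3-methoxyphenyl on a carbonyl carbon. Within the data shown here, no measured pair covers this exact exchange. Among the measured compounds shown here, the only step that touches the ring on the carbonyl carbon was flat, yet it was seen between two weak compounds, so it offers little guidance for compound 1. The expected step of a 3.0-fold higher number from compound 1 to compound 4 (0.48 log units; beyond the scatter) is a modest loss, with wide uncertainty. For compound 4 the estimate in this assay is 30 nM, with a range from 5 nM to 300 nM.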

Compound 4, effective concentration (reported as EC, without a stated level of effect): > 1000 nM
Compound 4: no number, only a limit; the forecaster's own chance of this, stated with the estimate: 5%; at least 33-fold (1.52 log units) between middle value and limit.
By their numbers in this assay, from the lowest: compound 1; then compounds 2 and 3 (each within the scatter of the next).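

In this assay, the ring on the carbonyl carbon proves to matter a great deal on the core of compound 1: an at least 100-fold higher number from compound 1 to compound 4 (2.00 log units; beyond the scatter). Going by these compounds, the reading for compound 4 is a limit of the assay and not a number, so the true size of this step stays unknown on the upper side: the limit of > 1000 nM in this assay, at which 1 of the 4 values shown sits. The earlier exchange on a carbonyl carbon, no change at the digits printed from compound 2 to compound 3 (within the scatter), joined two compounds with a different group on the other side of the core, whereas this pair differs in one place only and shows that, on the core of compound 1, pyridin-3-yl does not stand in for 3-methoxyphenyl, even though the two groups have the same counts of hydrogen-bond donors and acceptors and neither carries a net charge.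

This exchange removes the methoxy group and puts a nitrogen into the ring at the same time, so the compounds shown cannot say which of the two changes accounts for the step. A plain phenyl ring on the same carbonyl carbon, or a pyridin-3-yl ring that carries a methoxy group, would pull these two changes apart.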